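The compounds below may be only part of what the source reports. "The series", "measured", "known", "first", "only" and "open" are said of these compounds alone.

Measured so far in a functional assay on A549/CDDP cells (Homo sapiens) for antiproliferative activity, read by MTT assay, with a stated time of 72 h; on this read-out lower numbers stand for stronger inhibition and higher numbers for weaker inhibition:
- compound 1 `COc1cc(/C=C/C(=O)/C=C/c2nc(C)c(C)nc2C)ccc1O`: 600 nM
- compound 2 `COc1cccc(/C=C/C(=O)/C=C/c2nc(C)c(C)nc2C)c1O`: 2190 nM

Compound 2, at 2190 nM, has the higher of the two numbers in this assay and so is the weaker inhibitor of the pair. Compound 1, at 600 nM, lies below it by a gap beyond the usual scatter. Only these two values are available, so the series offers little to go on.

The next compound is compound 3 `COc1cccc(/C=C/C(=O)/C=C/c2nc(C)c(C)nc2C)c1`, still unmeasured. Its change from compound 2 is hydrogen in place of hydroxy on an aromatic carbon, ortho to a methoxy group. For the measured compounds named here, no measured pair shows what this exchange does in this assay, so the expectation is anchored on compound 2 at 2190 nM. A small move toward a higher number is expected, with no change beyond the scatter the most likely outcome. The expected shift is a 1.3-fold higher number from compound 2 to compound 3 (0.11 log units; within the scatter). The gap between the two measured values argues for a wide range. The estimate for compound 3 is 2800 nM, with an expected range of 900 nM to 8000 nM.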

Compound 3, half-maximal inhibitory concentration: 3440 nM
The estimate for compound 3 lay 1.2-fold (0.09 log units) below the measured number, and the stated range covers the measured number.
By their numbers in this assay, from the lowest: compound 1; then compounds 2 and 3 (each within the scatter of the next).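

In this assay, replacing hydroxy with hydrogen ortho to a methoxy group gives a 1.6-fold higher number from compound 2 to compound 3 (0.20 log units; within the scatter) and so does not separate the hydroxy of compound 2 from hydrogen at that place. The same kind of exchange starting from compound 1, where the hydroxy sits elsewhere on the ring but is also ortho to a methoxy group, gives a 5.7-fold higher number from compound 1 to compound 3 (0.76 log units; beyond the scatter) and so marks the hydroxy of compound 1 as the one whose loss shows in this read-out; the outcome of the exchange therefore depends on where the hydroxy stands, at least across these three compounds. Nothing at hand accounts for the difference between the two places.

The compounds shown leave open whether the hydroxy of compound 1 can be replaced by an amine, a carboxylic acid or a fluorine atom without the number rising to that of compound 3. They also leave open what the methoxy group contributes, since every compound here carries it and none has an ethoxy group or a hydrogen in its place.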